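The compounds below may be only part of what the source reports. "The series", "measured", "known", "first", "only" and "open" are said of these compounds alone.

Measured compounds:
compound 1, `COc1ccc2c(=O)c(/C=C/C(=O)Nc3cccc(Cl)c3)coc2c1`: 1100000 nM
compound 2, `COc1ccc2c(=O)c(/C=C/C(=O)Nc3ccccc3)coc2c1`: 523000 nM
compound 3, `COc1ccc2c(=O)c(/C=C/C(=O)NCc3ccccc3)coc2c1`: 376000 nM

In an ADME assay on HepG2 2.2.15 cells (Homo sapiens) for cytotoxicity, read by MTT assay, with stated times of 48 h and 9 days (on this read-out lower numbers stand for higher toxicity in this test and higher numbers for lower toxicity in this test), compound 1 gives the highest of the three numbers. Its nearest neighbour is compound 2, separated from it by a 2.1-fold lower number from compound 1 to compound 2 (0.32 log units; beyond the scatter). Compound 3 lies furthest away, with a 2.9-fold lower number from compound 1 to compound 3 (0.47 log units; beyond the scatter). Between the other two there is only a 1.4-fold lower number from compound 2 to compound 3 (0.14 log units; within the scatter), so compound 2 and compound 3 cannot be told apart on this read-out.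

Compound 4, `COc1ccc2c(=O)c(/C=C/C(=O)NCc3ccc(C)cc3)coc2c1`, has not yet been measured in this assay. It differs from compound 1 in one place: 4-methylbenzyl in place of 3-chlorophenyl on an amide-type nitrogen.

For the measured compounds named here, two measured steps bear on this change. Putting hydrogen in place of chloro gave a 2.1-fold lower number from compound 1 to compound 2 (0.32 log units; beyond the scatter), and putting benzyl in place of 3-chlorophenyl gave a 2.9-fold lower number from compound 1 to compound 3 (0.47 log units; beyond the scatter). Nothing measured tells what the methyl on the 4-methylbenzyl adds on its own, and the step of benzyl in place of phenyl, a 1.4-fold lower number from compound 2 to compound 3 (0.14 log units; within the scatter), gives no further push in either direction. The expected outcome is therefore a step of the same kind as that to compound 3, downward and modest. For compound 4 the expected step is a 2.9-fold lower number from compound 1 to compound 4 (0.46 log units; beyond the scatter). Compound 4 is accordingly estimated at 380000 nM, within a range from 160000 nM to 900000 nM.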

Compound 4, half-maximal cytotoxic concentration: 257000 nM
Estimate against measurement, compound 4: 1.5-fold (0.17 log units) above, within the range that was stated.
By their numbers in this assay, from the lowest: compounds 4, 3 and 2 (each within the scatter of the next, the first and the last beyond it); then compound 1.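

In this assay, methyl in place of hydrogen on an aromatic carbon gives a 1.5-fold lower number from compound 3 to compound 4 (0.17 log units; within the scatter), so this first measured look at a substituent on the benzyl ring shows no change that can be separated from the scatter. Even so, 4-methylbenzyl in place of phenyl on the amide-type nitrogen gives a 2.0-fold lower number from compound 2 to compound 4 (0.31 log units; beyond the scatter), a separation that benzyl alone did not produce, while 4-methylbenzyl in place of 3-chlorophenyl gives a 4.3-fold lower number from compound 1 to compound 4 (0.63 log units; beyond the scatter), so the 3-chlorophenyl compound remains apart from all three others. Nothing available explains why these numbers fall as they do.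

The compounds shown leave open whether a chloro on the benzyl ring would bring the number back towards that of compound 1, and so whether the chloro or the kind of group on the nitrogen matters more. They also leave open how an amine or a carboxylic acid on that ring, or a 2-phenylethyl group on the amide-type nitrogen, would read in this test.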